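Pyridine to hydroxyphenyl swap on the thioether carbon

The source may report more compounds than this note shows. Statements on the series, on what has been measured and on what is new or still open speak of the compounds shown alone.

Compound 1, `CC(Sc1nc2c(cnn2C)c(=O)n1-c1ccccc1)c1ccccn1`, gives 20000 nM in a physicochemical assay for solubility, using the shake flask method, in phosphate buffer, with a stated time of 24 h, at pH 7.4; a higher number here means a more soluble compound, a lower number a less soluble compound. For the measured compounds named here, it stands with the highest of the two numbers in hand, but its only neighbour, compound 2, `CC(Sc1nc2nn(C3(C)COC3)cc2c(=O)n1-c1ccccc1)c1ccccc1`, gives 19000 nM in this assay, and that gap lies within the scatter, so the two read as alike. Going by the values given here, no step between measured compounds that differ in one place is available; compounds 1 and 2 differ in several places, and their values show only that both sit in the same region.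

Compound 3, `CC(Sc1nc2c(cnn2C)c(=O)n1-c1ccccc1)c1cccc(O)c1`, has not yet been measured. Its difference from compound 1 is 3-hydroxyphenyl in place of pyridin-2-yl on a saturated chain carbon bound to a saturated chain carbon and a sulfur. Among the compounds with values here, with no comparable step in hand, the expectation for compound 3 in this assay is a step of a 1.1-fold lower number from compound 1 to compound 3 (0.05 log units; within the scatter) that is small or none beyond the scatter. Compound 3 is estimated at 18000 nM, with a range from 7000 nM to 45000 nM.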

Compound 3, solubility: 21000 nM
The estimate for compound 3 lay 1.2-fold (0.07 log units) below the measured number; the range from low to high includes it.
By their numbers in this assay, from the lowest: compounds 2, 1 and 3 (each within the scatter of the next).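

For the compounds shown here, at the saturated chain carbon bound to a saturated chain carbon and a sulfur, 3-hydroxyphenyl in place of pyridin-2-yl gives a 1.1-fold higher number from compound 1 to compound 3 (0.02 log units; within the scatter) in this assay, the first step that changes one place only. The exchange of a pyridine-type ring for a ring of carbon only, with a hydrogen-bond donor entering, therefore leaves no difference that can be told from the scatter at this position. No measurement at hand offers an explanation for this result.

Still open, as far as these compounds go, is whether a group of another kind on this carbon, such as an amine or a carboxylic acid at the end of a longer chain, would move the number beyond the scatter. Also open, from the compounds shown here alone, is whether the same exchange would read alike on a core carrying a different substituent.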